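Swapping the aryl group on the amine side chain

The source may hold more compounds than are shown below. What is called first, only, known or untested is meant among the compounds shown, and "the series" means these compounds.

Compound 2 `O=S(=O)(NCCCNCc1cccc2ccccc12)c1cc(C(F)(F)F)cc(C(F)(F)F)c1` carries a naphthalen-1-yl group on a saturated chain carbon bound to an amine nitrogen. Among the measured compounds shown here, in a functional assay on BE(2)-C cells (Homo sapiens) for inhibition, read by MTT assay, with a stated time of 72 h (on this read-out lower numbers stand for stronger inhibition of growth and higher numbers for weaker inhibition of growth), compound 2 gives 2700 nM, the higher of the two numbers measured so far, but only by a margin within the scatter, as compound 1 `CC(C)(C)c1ccc(CNCCCNS(=O)(=O)c2cc(C(F)(F)F)cc(C(F)(F)F)c2)cc1` gives 2500 nM in this assay. For the measured compounds named here, the single measured step, a 1.1-fold higher number from compound 1 to compound 2 (0.03 log units; within the scatter), shows that exchanging one aromatic group for another at this position left growth inhibition essentially unchanged. Compound 3 `COc1cccc(CNCCCNS(=O)(=O)c2cc(C(F)(F)F)cc(C(F)(F)F)c2)c1` differs from compound 2 by 3-methoxyphenyl in place of naphthalen-1-yl on a saturated chain carbon bound to an amine nitrogen. The earlier step swapped two groups without a hydrogen-bond acceptor, whereas here a group with one enters, so that step bears only loosely on this one; still, nothing measured points to a shift beyond the scatter. The expected step is therefore a 1.3-fold higher number from compound 2 to compound 3 (0.11 log units; within the scatter), no movement beyond the scatter. Compound 3 is estimated at 3500 nM in this assay, with a range from 1500 nM to 9000 nM.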

Compound 3, concentration for 50% growth inhibition: 4500 nM
Compound 3: middle estimate off by 1.3-fold (0.11 log units), on the low side; the measured number falls inside the stated range.
By their numbers in this assay, from the lowest: compounds 1, 2 and 3 (each within the scatter of the next).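

With 3-methoxyphenyl at this place, a 1.7-fold higher number from compound 2 to compound 3 (0.22 log units; within the scatter) in this assay is read alongside a 1.8-fold higher number from compound 1 to compound 3 (0.26 log units; within the scatter) and both stay within the scatter. The earlier step compared only groups without a hydrogen-bond acceptor, so this result adds something new: a group with one oxygen and a single aromatic ring gives a number that cannot be told apart from those of the naphthalen-1-yl and 4-(tert-butyl)phenyl compounds. No measurement available here explains why these three groups read alike.

From the compounds shown here alone, all three compounds keep an aromatic carbon ring at this place, so how a cyclohexyl or a pyridyl group would read there stays open. Also open, going by these compounds, is whether any group on this saturated chain carbon can move the number beyond the scatter.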